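Trifluoromethyl for fluoro on the core of compound 2

A few compounds are considered here, and "the series" means these few. Any claim that something is new, unique, unknown or untested is made for them only; others in the source may bear on it.

Measured compounds and their readings:
compound 1 `Cc1ccc2nc(C(=O)Nc3c(F)cc(-c4cccc(F)c4)cc3F)c(C)c(C(=O)O)c2c1` gives 1.05%
compound 2 `Cc1c(C(=O)Nc2c(F)cc(-c3cccc(F)c3)cc2F)nc2ccc(F)cc2c1C(=O)O` gives -0.13%

The account concerns a functional assay on Hep 3B2 cells (Homo sapiens) for antiproliferative activity, read by MTT assay, with a stated time of 24 h, tested at 0.02 ug/mL; a higher number here means a stronger effect of the compound at the concentration tested, a lower number a weaker effect. Compound 2 stands lowest of the two numbers, with compound 1 nearest; the step between them, a number 1.2 percentage points lower from compound 1 to compound 2 (within the scatter), lies within the scatter, so the two values cannot be told apart and neither compound can be called stronger or weaker. Both readings are near zero at the concentration tested.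

Compound 3 `Cc1c(C(=O)Nc2c(F)cc(-c3cccc(F)c3)cc2F)nc2ccc(C(F)(F)F)cc2c1C(=O)O` is not yet measured. Its change from compound 2 is trifluoromethyl in place of fluoro on an aromatic carbon. For the measured compounds named here, the only measured step, a number 1.2 percentage points lower from compound 1 to compound 2 (within the scatter), is the one that bears on it, since it is the step that placed the fluoro which now leaves, and it did not move the number beyond the scatter. There is therefore no measured ground for expecting a step of any size in this assay, and none beyond the scatter is expected. Compound 3 is accordingly estimated at 0.5%, with a range from -8% to 9%, which means an expected step of a number 0.6 percentage points higher from compound 2 to compound 3 (within the scatter).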

Compound 3, a percentage reported as inhibition, at one concentration (the size of the read-out at that concentration, not a potency): 1.15%
Compound 3: the middle estimate sits 0.7 percentage points below what was measured, within the range that was stated.
By their numbers in this assay, from the lowest: compounds 2, 1 and 3 (each within the scatter of the next).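

In this assay, the place on the core that carried methyl in compound 1 and fluoro in compound 2 now also carries trifluoromethyl, and the new steps are a number 1.3 percentage points higher from compound 2 to compound 3 (within the scatter) and a number 0.1 percentage points higher from compound 1 to compound 3 (within the scatter) within the shared core. With compound 3 at 1.15% as its reading, trifluoromethyl joins methyl and fluoro as a third group whose reading cannot be told apart from the others at this place, on an aromatic carbon of the six-membered aromatic ring of carbon only, so the flat result now holds across all three compounds rather than a single pair. Nothing measured speaks to why these readings stay together, and no supporting data bear on this result.

Because all three readings lie so close to zero, the compounds leave open whether this place is truly indifferent to its substituent or whether the single low test concentration simply cannot separate them. They also leave open whether an amine, a methoxy group or a longer alkyl chain at the same place would give a reading beyond the scatter.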